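The compounds below may be only part of what the source reports. "The series", "measured", "known", "first", "only" and "open" are said of these compounds alone.

Compound 1 `Cc1ccc(S(=O)(=O)N2C(=O)COC23C=CC(=O)C=C3)cc1`: 180 nM
Compound 2 `O=C1C=CC2(C=C1)OCC(=O)N2S(=O)(=O)c1ccccc1`: > 10000 nM, a limit of the assay
Compound 3 `Cc1ccc(S(=O)(=O)N2C(=O)C(C)OC23C=CC(=O)C=C3)cc1`: not yet measured

Among the measured compounds shown here, in a functional assay on HeLa cells (Homo sapiens) for inhibition, read by sulforhodamine B assay, with a stated time of 74 h (on this read-out higher numbers stand for weaker inhibition and lower numbers for stronger inhibition), compound 1 holds the only actual number, since the other value is a limit. The change to compound 3 is methyl in place of hydrogen on a saturated ring carbon. For the measured compounds named here, the single measured step, an at least 55-fold higher number from compound 1 to compound 2 (1.74 log units; beyond the scatter), is large, but it concerns a methyl on an aromatic carbon, so it gives no direction for this site. A small move towards a higher number is expected, most likely within the scatter. Compound 3 is estimated at 300 nM, with an expected range of 60 nM to 2000 nM. The expected step is a 1.7-fold higher number from compound 1 to compound 3 (0.22 log units; within the scatter).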

Compound 3, half-maximal inhibitory concentration: > 10000 nM
Compound 3: a limit, no number (the forecaster's own chance of this, stated with the estimate: 10%); at least 33-fold (1.52 log units) between middle value and limit.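

In this assay, this saturated ring carbon next to the ring oxygen proves sensitive to a single added methyl, with an at least 55-fold higher number from compound 1 to compound 3 (1.74 log units; beyond the scatter). The earlier compounds shown here showed such sensitivity only at the aromatic carbon, so the site joins it as a second place where a small change to compound 1 removes the measurable number. Both changes end at the same assay limit, so neither step has a true size that can be read: the limit of > 10000 nM in this assay, at which 2 of the 3 values shown sit.

From the compounds shown here alone, what a fluorine atom or a hydroxyl group on this saturated ring carbon would give remains open. So does the position of compound 3 beyond the limit.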